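This account rests on a few compounds, and the source may have more. Where it says the series, first, only, none or still open, it means among the compounds named here.

For the measured compounds named here, in a functional assay on CCRF-CEM cells (Homo sapiens) for antiproliferative activity, read by fluorescence and resazurin assay, with a stated time of 48 h (a higher number here means a weaker inhibitor, a lower number a stronger inhibitor), compound 1 (`CCOc1ccc(NC(=O)c2cc3cc(Br)ccc3oc2=O)cc1`) gives 21800 nM and compound 2 (`Cc1noc(NS(=O)(=O)c2ccc(NC(=O)c3cc4cc([N+](=O)[O-])ccc4oc3=O)cc2)c1C`) gives 14300 nM as the only other number, so the two lie within the usual scatter of each other. Compound 3 (`CCOc1ccc(NC(=O)c2cc3cc([N+](=O)[O-])ccc3oc2=O)cc1`) differs from compound 2 by one change (ethoxy in place of (3,4-dimethyl-1,2-oxazol-5-yl)sulfamoyl on an aromatic carbon) with ethoxy in place of (3,4-dimethyl-1,2-oxazol-5-yl)sulfamoyl on an aromatic carbon. Compound 1 also carries ethoxy and gives 21800 nM here, so no step beyond the scatter is expected in this assay for this change. The expected move is a 1.3-fold higher number from compound 2 to compound 3 (0.10 log units; within the scatter) and stays inside the scatter. Compound 3 is estimated at 18000 nM with an expected range from 7000 nM to 45000 nM for the measurement.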

Compound 3, half-maximal inhibitory concentration: 13200 nM
Estimate against measurement, compound 3: 1.4-fold (0.13 log units) above, and the stated range covers the measured number.
By their numbers in this assay, from the lowest: compounds 3, 2 and 1 (each within the scatter of the next).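

In this assay, putting the small ethoxy in place of the large (3,4-dimethyl-1,2-oxazol-5-yl)sulfamoyl gives a 1.1-fold lower number from compound 2 to compound 3 (0.03 log units; within the scatter), so this large exchange at this place on the aromatic ring leaves no readable difference. Nitro in place of bromo, a second single change on the shared core, gives a 1.7-fold lower number from compound 1 to compound 3 (0.22 log units; within the scatter), so that exchange leaves none either. Nothing measured here accounts for these small steps. Still open, as far as these compounds go, is whether an amine, a carboxylic acid or a longer chain in place of ethoxy would move the number beyond the scatter.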